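Toward Compound 4: 3-Nitrophenyl Replaces 4-(Trifluoromethyl)phenyl

A few compounds are considered here, and "the series" means these few. Any claim that something is new, unique, unknown or untested is made for them only; others in the source may bear on it.

Measured so far in a functional assay on MOLT-4 cells (Homo sapiens) for antiproliferative activity; on this read-out higher numbers stand for weaker inhibition and lower numbers for stronger inhibition:
Compound 1 `COc1cc(C(=O)c2sc(-c3ccc(Cl)cc3)cc2N)cc(OC)c1OC`: 77 nM
Compound 2 `COc1cc(C(=O)c2sc(-c3ccc(F)cc3)cc2N)cc(OC)c1OC`: 12 nM
Compound 3 `COc1cc(C(=O)c2sc(-c3ccc(C(F)(F)F)cc3)cc2N)cc(OC)c1OC`: 250 nM

Compound 3 stands highest of the three numbers: a 3.2-fold higher number from compound 1 to compound 3 (0.51 log units; beyond the scatter), and a 21-fold higher number from compound 2 to compound 3 (1.32 log units; beyond the scatter). Compound 4 `COc1cc(C(=O)c2sc(-c3cccc([N+](=O)[O-])c3)cc2N)cc(OC)c1OC` differs from compound 3 in one place: 3-nitrophenyl in place of 4-(trifluoromethyl)phenyl on an aromatic carbon. Among the compounds with values here, no measured step exchanges one phenyl group for another of this kind, so the bearing is indirect. Both steps that altered the group on the phenyl ring, a 6.4-fold lower number from compound 1 to compound 2 (0.81 log units; beyond the scatter) and a 3.2-fold higher number from compound 1 to compound 3 (0.51 log units; beyond the scatter), moved the number beyond the scatter, so a shift is expected here too, and with compound 3 the weakest point so far a modest move toward lower numbers seems more likely than a further rise. Compound 4 is therefore estimated at 100 nM, in the range 20 nM to 500 nM. This estimate means an expected 2.5-fold lower number from compound 3 to compound 4 (0.40 log units; beyond the scatter).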

Compound 4, half-maximal inhibitory concentration: 7.5 nM
Compound 4: the middle estimate sits 13-fold (1.12 log units) above what was measured, outside the stated range (below it).
By their numbers in this assay, from the lowest: compounds 4 and 2 (each within the scatter of the next); then compound 1; then compound 3.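

In this assay, the position next to the ring sulfur accepts 3-nitrophenyl, which differs from the three 4-substituted phenyl groups before it: a 33-fold lower number from compound 3 to compound 4 (1.52 log units; beyond the scatter) and a 10-fold lower number from compound 1 to compound 4 (1.01 log units; beyond the scatter) are both large steps. Compound 4 matches the 4-fluorophenyl compound, with a 1.6-fold lower number from compound 2 to compound 4 (0.20 log units; within the scatter). Nothing available explains these differences.

Going by these compounds, whether the nitro group itself or its place on the phenyl ring drives the change remains open. On these data alone, it is also open how an amine or a carboxylic acid on that ring would compare.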